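The compounds below may be only part of what the source reports. "The series", "measured", "known", "first", "only" and "open" are said of these compounds alone.

For the measured compounds named here, in a functional assay on CHO-K1 cells for antagonist activity at transient receptor potential cation channel subfamily V member 1 (Homo sapiens), read by FLIPR (on this read-out higher numbers stand for weaker inhibition and lower numbers for stronger inhibition), compound 1 `CC(C(=O)NCc1ccc(C(F)(F)F)nc1NCc1ccccc1)c1ccc(NS(C)(=O)=O)c(F)c1` gives 203 nM, the highest number of the three measured so far: compound 2 `CC(C(=O)NCc1ccc(C(F)(F)F)nc1N(C)c1ccccc1)c1ccc(NS(C)(=O)=O)c(F)c1` gives 57.4 nM and compound 3 `Cc1ccc(CC2CCN(c3nc(C(F)(F)F)ccc3CNC(=O)C(C)c3ccc(NS(C)(=O)=O)c(F)c3)CC2)cc1` gives 17 nM. Compound 4 `CC(=O)OC1CCN(c2nc(C(F)(F)F)ccc2CNC(=O)C(C)c2ccc(NS(C)(=O)=O)c(F)c2)CC1` differs from compound 1 by 4-acetoxypiperidin-1-yl in place of benzylamino on an aromatic carbon. Going by the values given here, one measured step bears on this change, a 3.5-fold lower number from compound 1 to compound 2 (0.55 log units; beyond the scatter), with methyl(phenyl)amino in place of benzylamino on the same aromatic carbon. Among the compounds with values here, compound 3, which likewise carries a piperidin-1-yl on an aromatic carbon of the shared core, shows a lower number again; no step to it is computed. A lower number beyond the scatter is therefore expected for compound 4, as a step of a 4.1-fold lower number from compound 1 to compound 4 (0.61 log units; beyond the scatter). The estimate for compound 4 is 50 nM, within 15 nM to 160 nM.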

Compound 4, half-maximal inhibitory concentration: 139 nM
Compound 4: the middle estimate sits 2.8-fold (0.44 log units) below what was measured, within the range that was stated.
By their numbers in this assay, from the lowest: compound 3; then compound 2; then compounds 4 and 1 (each within the scatter of the next).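

On the aromatic carbon next to the ring nitrogen, 4-acetoxypiperidin-1-yl and benzylamino cannot be told apart in this assay (a 1.5-fold lower number from compound 1 to compound 4 (0.16 log units; within the scatter)), so a piperidin-1-yl at this place does not by itself lower the number. The substituent on the saturated ring carbon matters, with acetoxy in place of 4-methylbenzyl (an 8.2-fold higher number from compound 3 to compound 4 (0.91 log units; beyond the scatter)), and the new group also falls short of methyl(phenyl)amino (a 2.4-fold higher number from compound 2 to compound 4 (0.38 log units; beyond the scatter)). No measurement at hand accounts for these differences.

Open, on these data alone, is how a hydroxy group, an amine or an unsubstituted benzyl group on that saturated ring carbon would read.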